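One Inverted Stereocentre, Same Atoms and Bonds

The source may report more compounds than this note shows. Statements on the series, on what has been measured and on what is new or still open speak of the compounds shown alone.

In a functional assay on MDA-MB-231 cells (Homo sapiens) for cytotoxicity, read by sulforhodamine B assay (a higher number here means a weaker inhibitor of growth, a lower number a stronger inhibitor of growth), compound 1 `COC1=C(Br)[C@H](O)[C@@]2(C=C1Br)CC(C(=O)NCCCCNC(=O)C1=NO[C@]3(C=C(Br)C(=O)[C@@H](Br)[C@@H]3O)C1)=NO2` gives 3500 nM and compound 2 `COC1=C(Br)[C@H](O)[C@@]2(C=C1Br)CC(C(=O)NCCCCCNC(=O)C1=NO[C@]3(C=C(Br)C(OC)(OC)[C@@H](Br)[C@@H]3O)C1)=NO2` gives 4200 nM, so the two sit within the usual scatter of each other. Compound 3 `COC1=C(Br)[C@H](O)[C@@]2(C=C1Br)CC(C(=O)NCCCCNC(=O)C1=NO[C@]3(C=C(Br)C(=O)[C@H](Br)[C@@H]3O)C1)=NO2` is the mirror-type variant of compound 1 at a single centre (the two compounds have the same atoms and bonds and differ only in configuration as drawn: 1 of 5 stereo elements differ; a stereocentre at a saturated ring carbon is drawn S in compound 1 and R in compound 3). Among the compounds with values here, no measured pair here shows what such an inversion does, so only a modest expectation is possible in this assay: a small loss of growth inhibition, most likely not beyond the scatter (a 1.3-fold higher number from compound 1 to compound 3 (0.11 log units; within the scatter)). Compound 3 is estimated at 4500 nM (range 1800 nM to 11000 nM).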

Compound 3, concentration for 50% growth inhibition: 2900 nM
The estimate for compound 3 lay 1.6-fold (0.19 log units) above the measured number, and the stated range covers the measured number.
By their numbers in this assay, from the lowest: compounds 3, 1 and 2 (each within the scatter of the next).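

Inverting this one saturated ring carbon from S to R gives a 1.2-fold lower number from compound 1 to compound 3 (0.08 log units; within the scatter) in this assay. The earlier compounds shown here held no such pair, and here the two configurations at this centre cannot be told apart in growth inhibition. Any reading of this step rests on one clean comparison: the fact that compounds 1 and 3 differ only in the configuration as drawn.

The compounds shown leave open whether the other stereocentres are just as forgiving in this assay. They also leave open what an amine or a carboxylic acid on the shared core would give.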